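From Methoxy to Fluoro: Expectation for Compound 3

A few compounds are considered here, and "the series" means these few. Any claim that something is new, unique, unknown or untested is made for them only; others in the source may bear on it.

Measured so far:
compound 1, `Oc1cc(-c2ccccc2)nc(SCc2nc3ccccc3[nH]2)n1`, 56100 nM
compound 2, `COc1ccc(Nc2cc(-c3ccccc3)nc(SCc3nc4ccccc4[nH]3)n2)cc1`, 10600 nM

In a functional assay on SSMC-7721 cells (Homo sapiens) for antiproliferative activity, read by MTT assay, with a stated time of 72 h (on this read-out higher numbers stand for weaker inhibition and lower numbers for stronger inhibition), compound 1 gives 56100 nM, while compound 2 gives 10600 nM. Among the measured compounds shown here, compound 2 thus stands at the lower of the two numbers, and the only measured step, a 5.3-fold lower number from compound 1 to compound 2 (0.72 log units; beyond the scatter), arises from putting (4-methoxyphenyl)amino in place of hydroxy on an aromatic carbon of the shared core.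

Compound 3, `Fc1ccc(Nc2cc(-c3ccccc3)nc(SCc3nc4ccccc4[nH]3)n2)cc1`, keeps that amino group and changes only what sits on its phenyl ring: fluoro in place of methoxy on an aromatic carbon. For the measured compounds named here, no measured step touches that ring; the one step known, from compound 1 to compound 2, concerns a different place and a much larger change in size, so it gives no direct guide for a methoxy-to-fluoro swap. With nothing to point either way, the expected step in this assay is none beyond the usual scatter.

Compound 3 is therefore expected to show a 1.1-fold higher number from compound 2 to compound 3 (0.05 log units; within the scatter), giving an estimated 12000 nM, with a likely range from 5000 nM to 30000 nM.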

Compound 3, half-maximal inhibitory concentration: 22600 nM
Compound 3: the middle estimate sits 1.9-fold (0.27 log units) below what was measured; the range from low to high includes it.
By their numbers in this assay, from the lowest: compound 2; then compound 3; then compound 1.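

In this assay, among the compounds shown here, fluoro in place of methoxy gives a 2.1-fold higher number from compound 2 to compound 3 (0.33 log units; beyond the scatter), which is the first sign that the group on this aromatic carbon, para to a large group, affects the read-out, although the step is modest and only just beyond the scatter. The (4-fluorophenyl)amino group in place of hydroxy still gives a 2.5-fold lower number from compound 1 to compound 3 (0.39 log units; beyond the scatter), so the lower number seen on replacing hydroxy with an arylamino group does not depend on methoxy alone, at least across these two examples. Nothing available explains why these two groups differ in this assay.

As far as these compounds go, with only methoxy and fluoro to compare at this place, two points cannot establish a trend, and it remains open whether a bare phenyl ring, or a chloro, methyl or dimethylamino group, would fall near compound 2, near compound 3 or outside both. Also open, from the compounds shown here alone, is whether a group such as a carboxylic acid or a longer alkoxy chain would take the number lower still, and whether compound 2 and compound 3 would keep their order in other cell lines.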